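Sulfonyl substituent swaps on a cyanoguanidine series: microsomal stability

The source may report more compounds than this note shows. Statements on the series, on what has been measured and on what is new or still open speak of the compounds shown alone.

Measured compounds:
compound 1 `N#C/N=C(\NCc1ccc(S(=O)(=O)N2CC3CCC(C2)O3)cc1)Nc1ccncc1`: 12%
compound 2 `N#C/N=C(\NCc1ccc(S(=O)(=O)c2cccc3cccnc23)cc1)Nc1ccncc1`: 11%

In an ADME assay on microsomes from liver (Mus musculus) for metabolic stability, with a stated time of 30 min, tested at 1 uM (on this read-out lower numbers stand for a less stable compound and higher numbers for a more stable compound), compound 1 gives 12% and compound 2 gives 11%; the two values lie within the scatter of each other, a number 1 percentage points lower from compound 1 to compound 2 (within the scatter). Compound 3 `N#C/N=C(\NCc1ccc(S(=O)(=O)C2CCCCC2)cc1)Nc1ccncc1` carries cyclohexyl in place of quinolin-8-yl on a sulfonyl sulfur. Within the data shown here, the one step on the sulfonyl sulfur, a number 1 percentage points lower from compound 1 to compound 2 (within the scatter), stayed within the scatter, so for a further swap at the same place no step beyond the scatter is expected in this assay ; the expected change is a number 1 percentage points higher from compound 2 to compound 3 (within the scatter). For compound 3 the value is estimated at 12%, in a range from 4% to 28%.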

Compound 3, percent of the compound remaining in the Mus musculus assay: 0.3%
The estimate for compound 3 lay 11.7 percentage points above the measured number, and the stated range ends above it.
By their numbers in the Mus musculus assay, from the lowest: compound 3; then compounds 2 and 1 (each within the scatter of the next).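

In the Mus musculus assay the place on the sulfonyl sulfur now moves the read-out beyond the scatter, with a number 10.7 percentage points lower from compound 2 to compound 3 (beyond the scatter) and a number 11.7 percentage points lower from compound 1 to compound 3 (beyond the scatter). In a physicochemical assay for solubility, with a stated time of 24 h (on this read-out lower numbers stand for lower solubility and higher numbers for higher solubility), the same swap moves the number the other way, with an at least 5.5-fold higher number from compound 2 to compound 3 (0.74 log units; beyond the scatter). In the physicochemical assay compound 2 gives 18000 nM. In the physicochemical assay compound 3 gives > 100000 nM, which is a limit of the assay and not a number: the limit of > 100000 nM in the physicochemical assay, at which 1 of the 2 values shown sits.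

The compounds shown do not separate the loss of the aromatic rings from the loss of the ring nitrogen. A phenyl group on the sulfonyl sulfur would bear on that question.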